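The compounds below may be only part of what the source reports. "The series", "measured", "known", "first", "only" and "open" are said of these compounds alone.

Measured so far:
Compound 1, `CCCCNc1nc(=O)c2cc([N+](=O)[O-])cc([N+](=O)[O-])c2s1`, gives "not determined" (no result reported).
Compound 2, `CC(C)CNc1nc(=O)c2cc([N+](=O)[O-])cc([N+](=O)[O-])c2s1`, gives "not determined" (no result reported).
Compound 3, `CC(C)CNc1nc(=O)c2cc(C(F)(F)F)cc([N+](=O)[O-])c2s1`, gives > 100000 nM.

Compound 3 stands at the limit of > 100000 nM in this assay, at which 1 of the 3 values shown sits. In an ADME assay on Vero cells (Chlorocebus sabaeus) for cytotoxicity, read by MTT assay, with a stated time of 72 h (on this read-out lower numbers stand for stronger inhibition and higher numbers for weaker inhibition), compound 3 gives > 100000 nM, which is a limit of the assay and not a number. Compound 1 and compound 2 carry no result in this assay, so compound 3 holds the only read-out in the series, and that read-out is a limit. Among the measured compounds shown here, no step between two measured compounds is available.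

Compound 4, `O=c1nc(N2CCCCC2)sc2c([N+](=O)[O-])cc(C(F)(F)F)cc12`, is not yet measured. It differs from compound 3 in one place: piperidin-1-yl in place of isobutylamino on an aromatic carbon. For the measured compounds named here, no measured pair connects an isobutylamino group to a piperidin-1-yl group, and no measured pair exists at all, so the size of the step cannot be read from data. The expectation is that the change leaves the result where it is, with compound 4 most likely again reported only as a limit. The step that the limit leaves unreadable from compound 3 to compound 4 is thus expected to be none beyond the scatter. Compound 4 is estimated at 150000 nM, with a range of 50000 nM to 500000 nM.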

Compound 4, half-maximal inhibitory concentration: > 100000 nM
Compound 4: a limit, no number; the forecaster's own chance of this, stated with the estimate: 75%; the middle value does not contradict the limit.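

In this assay no step can be read between compound 3 and compound 4, because each is reported only as a limit: the limit of > 100000 nM in this assay, at which 2 of the 4 values shown sit.

The compounds shown leave open how far piperidin-1-yl in place of isobutylamino moves the read-out, and whether any compound in the series gives a single number.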